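The source may hold more compounds than are shown below. What is called first, only, known or untested is meant among the compounds shown, and "the series" means these compounds.

Measured compounds:
Compound 1 `Cc1cccc(-n2nncc2CN2C(=O)C3(C(C#N)=C(N)Oc4c(N)cc5nc6ccccc6nc5c43)c3ccccc32)c1`: in a functional assay on MCF7 cells (Homo sapiens) for antiproliferative activity, read by MTT assay, with a stated time of 48 h (on this read-out lower numbers stand for stronger inhibition and higher numbers for weaker inhibition), compound 1 gives > 50000 nM, which is a limit of the assay.
Compound 2 `CCc1cccc(CC)c1-n1nncc1CN1C(=O)C2(C(C#N)=C(N)Oc3c(N)cc4nc5ccccc5nc4c32)c2ccccc21`: in this assay compound 2 gives > 50000 nM, again a limit and not a number.

Compound 2 therefore stands at the edge of what this assay reports, with no number of its own. Among the measured compounds shown here, the one measured step at this position, a step that the two limits leave unreadable from compound 1 to compound 2, cannot be sized because both of its ends sit at the limit of > 50000 nM in this assay, at which 2 of the 2 values shown sit.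

Compound 3 `Cc1ccc(Cl)cc1-n1nncc1CN1C(=O)C2(C(C#N)=C(N)Oc3c(N)cc4nc5ccccc5nc4c32)c2ccccc21` differs from compound 2 by 5-chloro-2-methylphenyl in place of 2,6-diethylphenyl on an aromatic nitrogen, in words 5-chloro-2-methylphenyl in place of 2,6-diethylphenyl on an aromatic nitrogen. For the measured compounds named here, the only measured step that touches this aromatic nitrogen is the one from compound 1 to compound 2, and its size stays unreadable because of the limit of > 50000 nM in this assay, at which 2 of the 2 values shown sit. No readable step is therefore available for this assay, and compound 3 is expected to remain where its two neighbours sit, with the step that the limit leaves unreadable from compound 2 to compound 3 meaning no change beyond the scatter. For compound 3 the expected value in this assay is 60000 nM, within 15000 nM to 200000 nM, most likely reported again only as a limit.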

Compound 3, half-maximal inhibitory concentration: 43500 nM
For compound 3 the middle estimate is 1.4-fold (0.14 log units) above the measured one; measured number inside the range.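

In this assay, among the compounds shown here, compound 3 gives a number of its own, 43500 nM, so a 5-chloro-2-methylphenyl group on the aromatic nitrogen gives the first reading at this position that is not a limit. Replacing 2,6-diethylphenyl gives an at least 1.1-fold lower number from compound 2 to compound 3 (0.06 log units; that floor lies within the scatter), and replacing 3-methylphenyl gives an at least 1.1-fold lower number from compound 1 to compound 3 (0.06 log units; that floor lies within the scatter). Each figure is only a floor, so neither change is shown to go beyond the scatter, and their true sizes stay unknown because the other end of both steps is a limit: the limit of > 50000 nM in this assay, at which 2 of the 3 values shown sit.

The compounds shown leave open whether the chlorine, the methyl group or their combination accounts for the measurable reading, as no compound here separates them. They also leave open how this position would read with an amine or a methoxy group on the phenyl ring, or with a cyclohexyl ring in place of the phenyl ring, and whether any such change would move the number beyond the scatter.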